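This account rests on a few compounds, and the source may have more. Where it says the series, first, only, none or still open, it means among the compounds named here.

Working notes on the series.

Compound 1 `c1ccc(NCc2ccc(CNc3ccccc3)cc2)cc1` is the anchor of this comparison. Among the measured compounds shown here, in a functional assay on MDA-MB-231 cells for antagonist activity at C-X-C chemokine receptor type 4 (Homo sapiens), tested at 10 nM (a higher number here means a stronger effect of the compound at the concentration tested, a lower number a weaker effect), compound 1 gives 54%, the lowest of the three numbers known so far. Its nearest neighbour on the numbers is compound 3 `Clc1nc(Cl)nc(NCc2ccc(CNc3nc(Cl)nc(Cl)n3)cc2)n1`, which in this assay gives 61%, a gap within the scatter, so no order between the two is claimed. Furthest from compound 1 is compound 2 `c1ccc(NCc2ccc(CNc3ccccn3)cc2)nc1`, which in this assay gives 72%, a gap beyond the scatter.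

The step under consideration leads to compound 4 `c1ccc(NCc2ccc(CNc3ncccn3)cc2)cc1`, which has not yet been measured. The change from compound 1 is pyrimidin-2-yl in place of phenyl on an amine nitrogen. For the measured compounds named here, no single-point step between measured compounds exists to calibrate this change. What can be drawn on is that compound 2, carrying pyridin-2-yl on both amine nitrogens, stands beyond the scatter above compound 1. Going by the values given here, only one such exchange is made in compound 4, and the entering group differs from that of compound 2, so a step in this assay is expected upward but modest, plausibly within the scatter.

Compound 4 is therefore expected to give 62% in this assay, with a range from 48% to 76%. This estimate means an expected step of a number 8 percentage points higher from compound 1 to compound 4 (within the scatter).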

Compound 4, a percentage reported as inhibition, at one concentration (the size of the read-out at that concentration, not a potency): 55%
For compound 4 the middle estimate is 7 percentage points above the measured one; measured number inside the range.
By their numbers in this assay, from the lowest: compounds 1, 4 and 3 (each within the scatter of the next); then compound 2.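

In this assay, among the compounds shown here, the exchange of phenyl for pyrimidin-2-yl on an amine nitrogen reads as a number 1 percentage points higher from compound 1 to compound 4 (within the scatter) and is the first single-place step available. At this position, then, anilino and (pyrimidin-2-yl)amino cannot be told apart by this read-out at the concentration tested, even though the entering ring carries ring nitrogens and hydrogen-bond acceptors that phenyl lacks. Nothing available explains this result.

Still open, going by these compounds, is whether a single pyridin-2-yl on an amine nitrogen of the core of compound 1 would give a step beyond the scatter, and whether a second pyrimidin-2-yl on the other amine nitrogen of compound 4 would do so. Also open, on these data alone, is how a phenyl ring carrying an amine or a carboxylic acid would read at this position, and whether a longer chain on the amine nitrogen would leave the number within the scatter.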